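The source may hold more compounds than are shown below. What is called first, only, known or untested is meant among the compounds shown, and "the series" means these compounds.

Compound 1 `CCOC(=O)[C@@H]1CCCN(S(=O)(=O)c2ccc(S(=O)(=O)N3CCOCC3)cc2)C1` is one of three compounds whose growth inhibition was followed in a functional assay on BXPC-3 cells (Homo sapiens) for inhibition, read by MTT assay, with a stated time of 7 days; on this read-out higher numbers stand for weaker inhibition and lower numbers for stronger inhibition. In this assay compound 1 gives 23400 nM, the higher of the two measured numbers. Compound 3 `CCN(CC)S(=O)(=O)c1ccc(S(=O)(=O)N2CCC[C@@H](c3nc(C)no3)C2)cc1` gives 2900 nM in this assay, a stronger result by a margin beyond the scatter. Compound 2 `CCOC(=O)[C@@H]1CCCN(S(=O)(=O)c2cccc(S(=O)(=O)N(CC)CC)c2)C1` reaches only a limit of the assay, > 30000 nM. One of the three results is thus a limit rather than a number (the limit of > 30000 nM in this assay, at which 1 of the 3 values shown sits).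

Compound 4 `CCOC(=O)[C@@H]1CCCN(S(=O)(=O)c2ccc(S(=O)(=O)N(CC)C(C)C)cc2)C1` has not yet been measured. It differs from compound 1 in one place: ethyl(isopropyl)amino in place of morpholin-4-yl on a sulfonyl sulfur. Within the data shown here, no measured pair among the three compounds differs in a single place, so the size of this change cannot be read from a measured step. Compound 3 is the stronger of the two numbered compounds, but it differs from compound 1 in more than one place, so only a small step is expected a 1.2-fold lower number from compound 1 to compound 4 (0.07 log units; within the scatter), within the scatter. Compound 4 is expected to give about 20000 nM in this assay, between 6000 nM and 40000 nM.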

Compound 4, half-maximal inhibitory concentration: 1600 nM
The estimate for compound 4 lay 13-fold (1.10 log units) above the measured number; the measured number lies below the stated range.
By their numbers in this assay, from the lowest: compounds 4 and 3 (each within the scatter of the next); then compound 1. At a limit, above all of these: compound 2.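

Among these compounds, putting ethyl(isopropyl)amino in place of morpholin-4-yl on a sulfonyl sulfur gives a 15-fold lower number from compound 1 to compound 4 (1.17 log units; beyond the scatter) in this assay, the first step in this set that can be read from a single change. The group on this sulfonyl sulfur is therefore not a silent part of compound 1: with the rest of the molecule unchanged, this one exchange moves the number well beyond the scatter. The entering group has no ring and no oxygen, whereas the leaving group has both, and this single step cannot separate the two differences.

As far as these compounds go, it remains open whether an open-chain group is what counts here, or whether a ring such as piperidin-1-yl, which lacks the oxygen of morpholin-4-yl, would give a similar number. Nothing among the compounds shown explains the size of this step.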